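Plasma unbound fraction across a small thiazolopyridinone urea series

This account rests on a few compounds, and the source may have more. Where it says the series, first, only, none or still open, it means among the compounds named here.

Measured so far:
compound 1 `CCNC(=O)Nc1nc2cc(-c3cccnc3)c(=O)n(CC)c2s1` — 0.11
compound 2 `CCNC(=O)Nc1nc2cc(-c3cccnc3)c(=O)n(CCC(C)C)c2s1` — 0.06

In an ADME assay on a cell-free system (plasma, Homo sapiens) (a higher number here means a larger unbound share of the compound, a lower number a smaller unbound share), compound 1 gives 0.11 and stands highest of the two numbers, though compound 2 is within the scatter of it, as a 1.8-fold lower number from compound 1 to compound 2 (0.26 log units; within the scatter) shows. Compound 3 `CCNC(=O)Nc1nc2cc(-c3cccnc3)c(=O)n(CC3CCOCC3)c2s1` is not yet measured. It differs from compound 1 by oxan-4-yl in place of methyl on a saturated chain carbon bound to an aromatic nitrogen. For the measured compounds named here, the only step that bears on it is the branch onto the same chain, a 1.8-fold lower number from compound 1 to compound 2 (0.26 log units; within the scatter), which stayed within the scatter. No shift beyond the scatter is therefore expected; for compound 3 the estimate is 0.09, between 0.05 and 0.17, a step of a 1.2-fold lower number from compound 1 to compound 3 (0.09 log units; within the scatter).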

Compound 3, unbound fraction in the plasma assay: 0.14
Beside the measured number, compound 3's estimate is 1.6-fold (0.19 log units) below it; the measured number falls inside the stated range.
By their numbers in the plasma assay, from the lowest: compounds 2, 1 and 3 (each within the scatter of the next, the first and the last beyond it).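

In the plasma assay, compound 3 carries oxan-4-yl where compound 1 carries methyl, and the step is a 1.3-fold higher number from compound 1 to compound 3 (0.10 log units; within the scatter), so a six-membered non-aromatic ring is accommodated there without a shift beyond the scatter. Oxan-4-yl in place of isobutyl gives a 2.3-fold higher number from compound 2 to compound 3 (0.37 log units; beyond the scatter), the first step beyond the scatter at this position. The same change from methyl does register in a physicochemical assay for solubility, in phosphate buffer, at pH 7.4 (on this read-out lower numbers stand for lower solubility and higher numbers for higher solubility), where compound 1 gives 94000 nM and compound 3 gives 25000 nM: the measured solubility of compound 1, 94000 nM, and of compound 3, 25000 nM, a 3.8-fold lower number (0.58 log units; beyond the scatter)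

Still open, as far as these compounds go, is whether cyclohexyl, without the ring oxygen, would read like oxan-4-yl in the plasma assay. An amine or a carboxylic acid on this chain also remains to be placed against compound 1.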